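The source may report more compounds than this note shows. Statements on the series, on what has been measured and on what is new or still open speak of the compounds shown alone.

Measured so far in a functional assay on PC-9 cells (Homo sapiens) for antiproliferative activity, read by MTT assay; on this read-out higher numbers stand for weaker inhibition and lower numbers for stronger inhibition:

- compound 1 `C#CCSc1nc(Sc2nncs2)c(C#N)c(-c2cc(OC)c(OC)c(OC)c2)n1` gives 7960 nM
- compound 2 `C=CC(=O)Nc1ccccc1CN(C(=O)Nc1cccc(C(F)(F)F)c1)C1CCN(C(C)CCC)CC1` gives 5590 nM
- compound 3 `C#CCSc1nc(Sc2nc[nH]n2)c(C#N)c(-c2cc(OC)c(OC)c(OC)c2)n1` gives > 20000 nM

The value of compound 3 is a limit and not a number: compound 3 stands at the limit of > 20000 nM in this assay, at which 1 of the 3 values shown sits.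

Compound 4 `C#CCSc1nc(Sc2nc(C)cs2)c(C#N)c(-c2cc(OC)c(OC)c(OC)c2)n1` is still unmeasured, and its change is 4-methyl-1,3-thiazol-2-yl in place of 1H-1,2,4-triazol-3-yl on a sulfur. Going by the values given here, one measured step bears on this sulfur: an at least 2.5-fold higher number from compound 1 to compound 3 (0.40 log units; beyond the scatter), where 1H-1,2,4-triazol-3-yl came in place of 1,3,4-thiadiazol-2-yl. Among the compounds with values here, compound 4 gives up that same triazolyl group, so a modest move toward a lower number is expected, though only this one step supports it. The expected move is an at least 2.5-fold lower number from compound 3 to compound 4 (0.39 log units; beyond the scatter) in this assay. For compound 4 the estimate is 8000 nM, with an expected range of 2500 nM to 20000 nM.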

Compound 4, half-maximal inhibitory concentration: > 20000 nM
Compound 4: no number, only a limit; the forecaster's own chance of this, stated with the estimate: 20%; middle value at least 2.5-fold (0.39 log units) from the limit.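

In this assay compound 4 gives a limit and not a number: the limit of > 20000 nM in this assay, at which 2 of the 4 values shown sit. The step between compound 3 and compound 4 therefore cannot be read, but a second replacement of 1,3,4-thiadiazol-2-yl on this sulfur now shows an at least 2.5-fold higher number from compound 1 to compound 4 (0.40 log units; beyond the scatter). The loss thus appears both with 1H-1,2,4-triazol-3-yl, which has a hydrogen-bond donor, and with 4-methyl-1,3-thiazol-2-yl, which has none. From the compounds shown here alone, how far compound 3 and compound 4 lie beyond the limit stays open. So does whether 5-methyl-1,3,4-thiadiazol-2-yl or 1,3,4-oxadiazol-2-yl on this sulfur would match or improve on compound 1.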